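Acetamidomethyl on the distal phenyl of compound 1

The source may hold more compounds than are shown below. What is called first, only, known or untested is meant among the compounds shown, and "the series" means these compounds.

Compound 1 `O=C(O)CC/C=C\CO[C@H]1C(OCc2ccc(-c3ccccc3)cc2)CC[C@@H]1N1CCCCCC1` gives 12.6 nM in a functional assay on blood for antagonist activity at thromboxane A2 receptor (Homo sapiens) (a higher number here means weaker binding, a lower number tighter binding), the highest of the two single numbers in the set. Drawn with a defined configuration at the ring carbon that is left undefined in compound 1, compound 3 `O=C(O)CC/C=C\CO[C@H]1[C@@H](OCc2ccc(-c3ccccc3)cc2)CC[C@@H]1N1CCCCCC1` gives 5.01 nM; the step of a 2.5-fold lower number from compound 1 to compound 3 (0.40 log units; beyond the scatter) is modest and rests on a drawing difference, because of the fact that one of compounds 1 and 3 is drawn with a defined configuration and the other without, at the place where they differ. Compound 2 `O=C(O)CC/C=C\CO[C@H]1C(OCc2ccc(-c3ccccc3)cc2)CC[C@@H]1N1CCCCC1`, with a six-membered rather than a seven-membered amine ring, has several entries, 63.1 nM; 15.9 nM (2 entries); its entries scatter around compound 1 and allow no statement of order, as the several entries of compound 2 in this assay, 63.1 nM; 15.9 nM (2 entries) shows.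

Compound 4 `CC(=O)NCc1ccc(-c2ccc(COC3CC[C@H](N4CCCCCC4)[C@H]3OC/C=C\CCC(=O)O)cc2)cc1` differs from compound 1 only at the remote aromatic ring: acetamidomethyl in place of hydrogen on an aromatic carbon. For the measured compounds named here, none of the measured steps touches this position; the one measured step concerns stereo drawing and the other pair concerns amine ring size, so neither gives a direction for a substituent on the biphenyl end. The expectation is therefore a step of a 1.1-fold lower number from compound 1 to compound 4 (0.02 log units; within the scatter), within the scatter, in this assay. Compound 4 is estimated at 12 nM, with a range from 4 nM to 40 nM, pending the measurement.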

Compound 4, dissociation constant: 2.51 nM
Compound 4: middle estimate off by 4.8-fold (0.68 log units), on the high side; measured number outside the range, below it.
By their numbers in this assay, from the lowest: compounds 4 and 3 (each within the scatter of the next); then compound 1.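

For the compounds shown here, the earlier compounds varied only the amine ring and the drawn configuration, so compound 4 gives the first reading on the distal phenyl, at the aromatic carbon para to a large group. In this assay, the change from phenyl to 4-(acetamidomethyl)phenyl gives a 5.0-fold lower number from compound 1 to compound 4 (0.70 log units; beyond the scatter), so this position accepts a substituent of this size, and here the number falls rather than rises. This rests on a single substituent at a single place, and nothing measured in the set accounts for the step.

An aminomethyl, a carboxylic acid or a longer chain at the same place would help show whether the lower number follows the whole acetamidomethyl group or only part of it, and whether the nitrogen and carbonyl both matter. On these data alone, it also remains open whether the same change would give a similar step on the six-membered amine ring of compound 2 or with the defined configuration of compound 3.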